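Pyrrolidin-1-yl replaces methylamino on compound 3

The source may hold more compounds than are shown below. What is called first, only, known or untested is meant among the compounds shown, and "the series" means these compounds.

Measured in a functional assay on the whole organism with Mus musculus as the target; on this read-out higher numbers stand for an effect only at larger amounts of compound and lower numbers for an effect already at smaller amounts:
- compound 1 `NC(=O)Cn1c(-c2ccc(C(F)(F)F)cc2)nc2cccnc21`: 11.7 mg/kg
- compound 2 `Cc1ccc(-c2nc3cccnc3n2CC(N)=O)cc1`: 50.5 mg/kg
- compound 3 `CNC(=O)Cn1c(-c2ccc(Cl)cc2)nc2cccnc21`: 12.5 mg/kg

Compound 3 lies within the scatter of compound 1, while compound 2 reads clearly higher than both. Compound 4 `O=C(Cn1c(-c2ccc(Cl)cc2)nc2cccnc21)N1CCCC1` differs from compound 3 by one change: pyrrolidin-1-yl in place of methylamino on a carbonyl carbon. For the measured compounds named here, no measured step touches this place. The only one, a 4.3-fold higher number from compound 1 to compound 2 (0.64 log units; beyond the scatter), concerns another group and serves at best as a yardstick of size. A step no larger than that yardstick is expected in this assay. Going by the values given here, no measured compound carries the new group, and the slight lean toward a higher number is a cautious guess. The expected change is a 1.6-fold higher number from compound 3 to compound 4 (0.20 log units; within the scatter). For compound 4 the estimated value is 20 mg/kg, with an expected range of 6 mg/kg to 65 mg/kg.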

Compound 4, dose for half-maximal effect: 17.9 mg/kg
Estimate against measurement, compound 4: 1.1-fold (0.05 log units) above, and the stated range covers the measured number.
By their numbers in this assay, from the lowest: compounds 1, 3 and 4 (each within the scatter of the next); then compound 2.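

In this assay, pyrrolidin-1-yl in place of methylamino on the carbonyl carbon gives a 1.4-fold higher number from compound 3 to compound 4 (0.16 log units; within the scatter), a step that stays within the scatter. At this position, then, the amide hydrogen of methylamino can be lost and a five-membered ring added without a clear shift in the dose needed. No measured property is available to explain this result. On these data alone, whether a six-membered ring such as piperidin-1-yl or morpholin-4-yl on this carbonyl would behave the same stays open. So does the outcome of replacing the amide with a carboxylic acid.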